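Swapping the amino for chloro on the cinnamamide triazole

A few compounds are considered here, and "the series" means these few. Any claim that something is new, unique, unknown or untested is made for them only; others in the source may bear on it.

Measured so far in an ADME assay on Vero cells (Chlorocebus sabaeus) for cytotoxicity, read by MTT assay, with a stated time of 72 h; a higher number here means that more compound is tolerated, a lower number that less compound is tolerated:
compound 1, `COc1ccc(/C=C/C(=O)Nc2nnc(-c3ccccc3)[nH]2)cc1OC`, gives 1210000 nM
compound 2, `Nc1ccc(/C=C/C(=O)Nc2nnc(-c3ccccc3)[nH]2)cc1`, gives 1910000 nM
compound 3, `O=C(/C=C/c1ccc(OC(F)(F)F)cc1)Nc1nnc(-c2ccccc2)[nH]1`, gives 1560000 nM

Compound 2 stands highest of the three numbers in this assay, but its nearest neighbour is compound 3 and its furthest is compound 1, and both gaps lie within the scatter, so the three compounds cannot be told apart on these data.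

The step to the unmeasured compound 4, `O=C(/C=C/c1ccc(Cl)cc1)Nc1nnc(-c2ccccc2)[nH]1`, is chloro in place of amino on an aromatic carbon. Going by the values given here, the one measured step that bears on it is a 1.2-fold lower number from compound 2 to compound 3 (0.09 log units; within the scatter), where a different group also replaced the amino at the same place and the number stayed within the scatter. Among the compounds with values here, only one such step is known, so the expectation rests on little.

The estimate for compound 4 in this assay is therefore no change beyond the scatter, a 1.2-fold lower number from compound 2 to compound 4 (0.08 log units; within the scatter), with an expected value of 1600000 nM and a range from 800000 nM to 3200000 nM.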

Compound 4, half-maximal cytotoxic concentration: 1620000 nM
The estimate for compound 4 lay 1.0-fold (0.01 log units) below the measured number; the range from low to high includes it.
By their numbers in this assay, from the lowest: compounds 1, 3, 4 and 2 (each within the scatter of the next).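

Going from 4-aminophenyl to 4-chlorophenyl in this assay (a 1.2-fold lower number from compound 2 to compound 4 (0.07 log units; within the scatter)) removes the hydrogen-bond donor and acceptor counted on the amino, yet the number stays within the scatter. Chloro and trifluoromethoxy cannot be told apart either (a 1.0-fold higher number from compound 3 to compound 4 (0.02 log units; within the scatter)), so three different groups at this place on the aromatic ring now lie within the scatter of one another, where the earlier compounds offered only one such replacement of the amino. Nothing at hand explains why this assay fails to separate them.

On these data alone, whether the same holds for a carboxylic acid, a nitrile or a longer chain such as butyl at this place remains open. These compounds also leave open how the number responds to changes elsewhere in the shared core.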